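Bromo in place of isopropyl on an aromatic carbon

The source may report more compounds than this note shows. Statements on the series, on what has been measured and on what is new or still open speak of the compounds shown alone.

In an in vitro ADME assay on microsomes from liver (Homo sapiens) for pharmacokinetics, read by LC-MS, with a stated time of 10 min, tested at 1 uM (a higher number here means faster removal of the compound, a lower number slower removal), compound 2 `CC(C)c1ccc(NC(=O)[C@H]2CN(C)C[C@@H]2c2ccc(/C=C/C(=O)Nc3ccccc3N)cc2)cc1` gives 10 mL/min/kg, and compound 1 `Cc1ccc(NC(=O)[C@H]2CN(C)C[C@@H]2c2ccc(/C=C/C(=O)Nc3ccccc3N)cc2)cc1` gives 15 mL/min/kg. For the measured compounds named here, these are the only two measured numbers, and the step between them, a 1.5-fold lower number from compound 1 to compound 2 (0.18 log units; within the scatter), does not set either compound apart from the other.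

Compound 3 `CN1C[C@H](C(=O)Nc2ccc(Br)cc2)[C@@H](c2ccc(/C=C/C(=O)Nc3ccccc3N)cc2)C1` keeps the shared core and differs at one place: bromo in place of isopropyl on an aromatic carbon. Going by the values given here, the one measured step at this place, isopropyl in place of methyl in compound 2, was a 1.5-fold lower number from compound 1 to compound 2 (0.18 log units; within the scatter). Among the compounds with values here, no bromo compound has a measured value, so this single step is a thin guide. No change beyond the scatter is therefore expected in this assay, and the expected step is a 1.3-fold higher number from compound 2 to compound 3 (0.11 log units; within the scatter). The estimated clearance of compound 3 is 13 mL/min/kg, with an expected range of 7 mL/min/kg to 24 mL/min/kg.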

Compound 3, clearance: 3 mL/min/kg
For compound 3 the middle estimate is 4.3-fold (0.64 log units) above the measured one; measured number outside the range, below it.
By their numbers in this assay, from the lowest: compound 3; then compounds 2 and 1 (each within the scatter of the next).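

For the compounds shown here, at this aromatic carbon the earlier pair gave no step that could be told from the scatter, so the position might have seemed to make little difference in this assay. The 4-bromophenyl compound changes that picture, showing a 3.3-fold lower number from compound 2 to compound 3 (0.52 log units; beyond the scatter) and a 5.0-fold lower number from compound 1 to compound 3 (0.70 log units; beyond the scatter) and so standing apart from both the isopropyl and the methyl compound. What sits on this carbon can therefore move the number beyond the scatter, although among these three compounds only bromo does so, and nothing in the data explains the shift.

On these data alone, whether this result belongs to bromo alone or extends to chloro, fluoro or methoxy remains open. So does the outcome with an amine or a carboxylic acid on the same carbon.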